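Swapping a rigid aryl arm for a flexible methylamino chain

The source may hold more compounds than are shown below. What is called first, only, known or untested is meant among the compounds shown, and "the series" means these compounds.

Compound 1 `NCc1ccccc1CN(Cc1nc2ccccc2[nH]1)C1CCCc2cccnc21` gives 50 nM in a functional assay on CEM-CCRF cells for antagonist activity at C-X-C chemokine receptor type 4 (Homo sapiens), read by calcium flux (on this read-out higher numbers stand for weaker inhibition and lower numbers for stronger inhibition), the lowest of the two numbers measured. Compound 2 `NCCCCCN(Cc1nc2ccccc2[nH]1)C1CCCc2cccnc21` gives 514 nM, and the step of a 10-fold higher number from compound 1 to compound 2 (1.01 log units; beyond the scatter) shows that replacing the aromatic arm with an open chain weakens inhibition markedly. Compound 3 `CNCCCCN(Cc1nc2ccccc2[nH]1)C1CCCc2cccnc21` carries a related change: 3-(methylamino)propyl in place of 2-(aminomethyl)phenyl on a saturated chain carbon bound to an amine nitrogen. Since the chain in compound 3 closely resembles that in compound 2, a comparable loss is expected, so the step of an 8.0-fold higher number from compound 1 to compound 3 (0.90 log units; beyond the scatter) is anticipated. Compound 3 is therefore estimated at 400 nM, with a likely range from 120 nM to 1500 nM.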

Compound 3, half-maximal inhibitory concentration: 190 nM
The estimate for compound 3 lay 2.1-fold (0.32 log units) above the measured number; measured number inside the range.
By their numbers in this assay, from the lowest: compound 1; then compound 3; then compound 2.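

In this assay, giving up the aromatic ring need not cost as much as compound 2 suggested: methylamino in place of aminomethyl on a saturated chain carbon, four bonds along the chain from an amine nitrogen, gives a 2.7-fold lower number from compound 2 to compound 3 (0.43 log units; beyond the scatter). Even so, the 2-(aminomethyl)phenyl arm keeps its lead, with a 3.8-fold higher number from compound 1 to compound 3 (0.58 log units; beyond the scatter). The size of the loss therefore depends on the end of the open chain, not only on the missing ring.

Nothing available explains either step. Going by these compounds, whether a dimethylamino end or a shorter chain would narrow the remaining gap to compound 1 stays open.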